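This account rests on a few compounds, and the source may have more. Where it says the series, first, only, none or still open, it means among the compounds named here.

In a functional assay on Bel-7402 cells (Homo sapiens) for cytotoxicity, read by MTT assay (a lower number here means a stronger inhibitor, a higher number a weaker inhibitor), compound 1 `CCn1cc(C(=O)Nc2ccccc2)c(=O)c2cc(F)c(N3CCNC(C)C3)c(F)c21` gives 6000 nM, and compound 2 `CCn1cc(C(=O)Nc2cc([N+](=O)[O-])ccc2F)c(=O)c2cc(F)c(N3CCNC(C)C3)c(F)c21` gives 2900 nM, with a 2.1-fold lower number from compound 1 to compound 2 (0.32 log units; beyond the scatter). For compound 3 `CCn1cc(C(=O)Nc2ccc(C(C)=O)cc2)c(=O)c2cc(F)c(N3CCNC(C)C3)c(F)c21`, the result is only a limit, > 50000 nM. Compound 3 is the weakest of the three, as the two steps leading to it show. Compound 4 `CCn1cc(C(=O)Nc2nccs2)c(=O)c2cc(F)c(N3CCNC(C)C3)c(F)c21` exchanges the group on the amide-type nitrogen: 1,3-thiazol-2-yl in place of 4-acetylphenyl on an amide-type nitrogen. The closest precedents are the acetyl addition, an at least 8.3-fold higher number from compound 1 to compound 3 (0.92 log units; beyond the scatter), and the change of ring substituents, an at least 17-fold higher number from compound 2 to compound 3 (1.23 log units; beyond the scatter). Going by these compounds, compound 4 carries no 4-acetylphenyl, so reversing those modest to large rises suggests a clear drop in this assay, although the new ring remains untested. The estimated step is an at least 5.0-fold lower number from compound 3 to compound 4 (0.69 log units; beyond the scatter). For compound 4, the estimated value is 10000 nM, with an expected range from 2500 nM to 40000 nM.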

Compound 4, half-maximal inhibitory concentration: > 50000 nM
Compound 4 was reported as a limit (the forecaster's own chance of this, stated with the estimate: 20%); at least 5.0-fold (0.69 log units) between middle value and limit.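

In this assay, losing the 4-acetylphenyl does not by itself bring the number back down, since 1,3-thiazol-2-yl on the amide-type nitrogen also compares poorly with phenyl and 2-fluoro-5-nitrophenyl, with an at least 8.3-fold higher number from compound 1 to compound 4 (0.92 log units; beyond the scatter) and an at least 17-fold higher number from compound 2 to compound 4 (1.23 log units; beyond the scatter). So two quite different groups at this position, one a five-membered ring with hetero atoms, now give weak results. Compound 3 and compound 4 cannot be ranked, and the step between them cannot be read, because both are reported only as limits: the limit of > 50000 nM in this assay, at which 2 of the 4 values shown sit.

Going by these compounds, it remains open how a pyridyl ring would behave on this nitrogen. The same goes for a phenyl ring carrying an amine or a carboxylic acid.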